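Moving a Fluorine on the Trifluoromethylphenyl Tail

The source may hold more compounds than are shown below. What is called first, only, known or untested is meant among the compounds shown, and "the series" means these compounds.

The measured compounds are two: compound 1, `CCc1nc(Cl)c2n1CCN([C@@H](C(=O)NC)c1ccccc1)[C@H]2CCc1cccc(C(F)(F)F)c1`, with 72 nM in a functional assay on CHO cells for antagonist activity at Orexin/Hypocretin receptor type 1 (Homo sapiens), read by FLIPR and calcium flux; a lower number here means a stronger inhibitor, a higher number a weaker inhibitor; and compound 2, `CCc1nc(Cl)c2n1CCN([C@@H](C(=O)NC)c1ccccc1)[C@H]2CCc1ccc(C(F)(F)F)c(F)c1F`, with 17 nM in this assay.

Compound 2 stands at the lower of the two numbers; the step of a 4.2-fold lower number from compound 1 to compound 2 (0.63 log units; beyond the scatter) lies beyond the scatter. Compound 3 is `CCc1nc(Cl)c2n1CCN([C@@H](C(=O)NC)c1ccccc1)[C@H]2CCc1cc(F)c(C(F)(F)F)cc1F`. Its difference from compound 2 is 2,5-difluoro-4-(trifluoromethyl)phenyl in place of 2,3-difluoro-4-(trifluoromethyl)phenyl on a saturated chain carbon, two bonds along the chain from a saturated ring carbon. Among the measured compounds shown here, no measured step bears directly on this change: the only step recorded, a 4.2-fold lower number from compound 1 to compound 2 (0.63 log units; beyond the scatter), adds two fluorines to the ring, whereas here the same atoms are merely joined differently. With the same number of fluorines and the same trifluoromethyl group, compound 3 is expected to stay near compound 2 in this assay, with the step of a 1.3-fold higher number from compound 2 to compound 3 (0.11 log units; within the scatter) estimated as within the scatter. For compound 3 the estimate in this assay is 22 nM, in the range 7 nM to 65 nM.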

Compound 3, half-maximal inhibitory concentration: 32 nM
Compound 3: middle estimate off by 1.5-fold (0.16 log units), on the low side; measured number inside the range.
By their numbers in this assay, from the lowest: compounds 2 and 3 (each within the scatter of the next); then compound 1.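

In this assay, the shift of one fluorine gives (a 1.9-fold higher number from compound 2 to compound 3 (0.27 log units; within the scatter)), which lies within the scatter, so the 2,3-difluoro-4-(trifluoromethyl)phenyl and 2,5-difluoro-4-(trifluoromethyl)phenyl groups cannot be told apart on this saturated chain carbon. The 2,5-difluoro-4-(trifluoromethyl)phenyl group also differs from the 3-(trifluoromethyl)phenyl group of compound 1 by (a 2.3-fold lower number from compound 1 to compound 3 (0.35 log units; beyond the scatter)), beyond the scatter, so the lower number is not confined to one difluoro arrangement. Nothing at hand explains these numbers.

The compounds shown leave open whether chlorine or methoxy in place of the two ring fluorines, or a nitrile in place of the trifluoromethyl, would hold numbers in this range. They also leave open whether a longer chain would carry the difluorinated ring equally well.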